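Four Compounds at the Ceiling of a Cell Assay

This account rests on a few compounds, and the source may have more. Where it says the series, first, only, none or still open, it means among the compounds named here.

Compound 1 `COCOc1cc(/C=C/C(=O)OCC(=O)Nc2ccc(OC)cc2)ccc1OCc1ccccc1`: in a functional assay on HL-60 cells (Homo sapiens) for cytotoxicity, read by MTT assay, with a stated time of 72 h (on this read-out higher numbers stand for weaker inhibition and lower numbers for stronger inhibition), compound 1 gives > 200000 nM, which is a limit of the assay rather than a number.
Compound 2 `COCOc1cc(/C=C/C(=O)OCC(=O)Nc2ccc(Cl)cc2)ccc1OCc1ccccc1`: in this assay compound 2 gives > 200000 nM, also a limit.
Compound 3 `COc1ccc(NC(=O)COC(=O)/C=C/c2cc(OC)c(OCc3ccc(Cl)c(Cl)c3)c(OC)c2)cc1`: in this assay compound 3 gives > 200000 nM, again a limit.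

Every measured value therefore sits at the same ceiling, (the limit of > 200000 nM in this assay, at which 3 of the 3 values shown sit), and none of them is a true number. From compound 1 to compound 2 the change is chloro in place of methoxy on an aromatic carbon. The step that the two limits leave unreadable from compound 1 to compound 2 stays unreadable because the limit of > 200000 nM in this assay, at which 3 of the 3 values shown sit, hides both ends of it. How the core of compound 3 differs from the core of compound 1 is not broken down here.

Compound 4 `COc1cc(/C=C/C(=O)OCC(=O)Nc2ccc(Cl)cc2)cc(OC)c1OCc1ccc(Cl)c(Cl)c1` has not yet been measured. It differs from compound 3 by chloro in place of methoxy on an aromatic carbon, the same change at the same kind of place as between compound 1 and compound 2. Because compound 3 gives > 200000 nM and the earlier step was swallowed by the ceiling, compound 4 is expected to stay at the limit as well, with an estimated value of 200000 nM. The step of a number no higher from compound 3 to compound 4 (the limit leaves the size open) is thus expected to be flat, in the sense that both ends are expected to lie beyond what this assay can report.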

Compound 4, half-maximal inhibitory concentration: 73900 nM
For compound 4 the middle estimate is 2.7-fold (0.43 log units) above the measured one; measured number below the stated range.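

As far as these compounds go, on the core of compound 3, chloro in place of methoxy gives an at least 2.7-fold lower number from compound 3 to compound 4 (0.43 log units; beyond the scatter) in this assay, so on this core the swap has a real effect on the read-out, and its full size stays open. The same swap on the core of compound 1 cannot be read, since compound 1 and compound 2 both sit at a limit, so nothing here shows that the change carries from one core to the other. One readable step on one core is not a rule for the series, and the comparison between the two cores fails because of the ceiling: the limit of > 200000 nM in this assay, at which 3 of the 4 values shown sit.

The compounds shown leave open whether another group at the same place, such as an amine, a carboxylic acid or a nitrile, would lower the number further or not at all. Also open, from the compounds shown here alone, is how far compound 3 lies beyond its limit, which sets the true size of the step.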